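Trimming the isopropyl from a triazole-linked nucleoside

The compounds below may be only part of what the source reports. "The series", "measured", "known", "first", "only" and "open" are said of these compounds alone.

Measured compounds:
- compound 1, `CC(=O)OC[C@H]1O[C@@H](n2cc(-c3cn(Cc4ccc(C(C)C)cc4)nn3)c(=O)[nH]c2=O)C[C@@H]1OC(C)=O`, 91.3%
- compound 2, `CC(=O)OC[C@H]1O[C@@H](n2cc(-c3cc(-c4ccc(C(C)(C)C)cc4)no3)c(=O)[nH]c2=O)C[C@@H]1OC(C)=O`, 27.5%
- compound 3, `CC(=O)OC[C@H]1O[C@@H](n2cc(-c3cc(C)no3)c(=O)[nH]c2=O)C[C@@H]1OC(C)=O`, 92.4%

All three share one nucleoside core and were tested in a functional assay on PC-3 cells (Homo sapiens) for cytotoxicity, read by sulforhodamine B assay, tested at 10 uM; a lower number here means less inhibition, a higher number more inhibition at the concentration tested (going by the name of the read-out). Compound 1 gives 91.3%, and compound 3 gives 92.4%; these two values lie within the usual scatter of one another. Compound 2 gives 27.5%, far below both. Going by the values given here, the only single-point step among the measured compounds is a number 64.9 percentage points higher from compound 2 to compound 3 (beyond the scatter), a large gain when a bulky aryl group is replaced by a small one on the five-membered ring.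

Compound 4, `CC(=O)OC[C@H]1O[C@@H](n2cc(-c3cn(Cc4ccccc4)nn3)c(=O)[nH]c2=O)C[C@@H]1OC(C)=O`, differs from compound 1 in one place: hydrogen in place of isopropyl on an aromatic carbon. The group is lost from an aromatic carbon of a six-membered aromatic ring of carbon only, not from the five-membered ring altered between compound 2 and compound 3, so that step does not bear directly on this change. What the numbers do show is that compound 1 already sits near the top of this assay, leaving little room for a further rise, and that the one shrinkage of a substituent seen here did not lower inhibition. A step of no size beyond the scatter is therefore expected: a number 5.3 percentage points lower from compound 1 to compound 4 (within the scatter). Compound 4 is estimated at 86%, with a range from 60% to 98%.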

Compound 4, a percentage reported as inhibition, at one concentration (the size of the read-out at that concentration, not a potency): 92.1%
Estimate against measurement, compound 4: 6.1 percentage points below, within the range that was stated.
By their numbers in this assay, from the lowest: compound 2; then compounds 1, 4 and 3 (each within the scatter of the next).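

In this assay, the step is a number 0.8 percentage points higher from compound 1 to compound 4 (within the scatter), so the isopropyl group on this aromatic carbon of a six-membered aromatic ring of carbon only can give way to hydrogen without a shift beyond the scatter. Going by these compounds alone, this is the first direct reading at this position: the earlier step, between compound 2 and compound 3, concerned a different group on the five-membered ring, whereas here the 4-isopropylbenzyl group of compound 1 and the plain benzyl group of compound 4 perform alike at the single concentration tested. No measurement shown here offers an explanation for this outcome.

With compound 1 at 91.3% and compound 4 at 92.1%, both lie close to the top of the percentage scale, so a reading at one concentration cannot tell whether the two would still match at lower concentrations, where one might show a stronger effect than the other. Going by these compounds, it also remains open whether this same position would accept a group of another kind, such as an amine, a carboxylic acid or a longer carbon chain, as readily as it accepts hydrogen or isopropyl.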